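Swapping 4-Methylbenzyl for 2-Methoxyphenyl on the Amide Nitrogen

A few compounds are considered here, and "the series" means these few. Any claim that something is new, unique, unknown or untested is made for them only; others in the source may bear on it.

Three compounds built on one shared core differ only in the group attached to the amide nitrogen. Compound 1 `C=CC1=C(C(=O)NCc2ccccc2)C(c2ccc(OC)cc2)OC1` carries a benzyl group there, and in a functional assay on QGY7701 cells (Homo sapiens) for cytotoxicity, read by MTT assay, with a stated time of 24 h (on this read-out lower numbers stand for stronger inhibition and higher numbers for weaker inhibition), compound 1 reaches only the limit of > 100000 nM. Compound 2 `C=CC1=C(C(=O)NCCCCC)C(c2ccc(OC)cc2)OC1` places butyl instead of phenyl on the saturated chain carbon bound to the amide-type nitrogen; in this assay compound 2 likewise stops at the limit of > 100000 nM. Within the data shown here, compound 3 `C=CC1=C(C(=O)NCc2ccc(C)cc2)C(c2ccc(OC)cc2)OC1` adds methyl in place of hydrogen on an aromatic carbon, and in this assay compound 3 gives 43100 nM, the single genuine number among the three. The other two values sit at the limit of > 100000 nM in this assay, at which 2 of the 3 values shown sit. The measured steps are an at least 2.3-fold lower number from compound 1 to compound 3 (0.36 log units; beyond the scatter) and an at least 2.3-fold lower number from compound 2 to compound 3 (0.36 log units; beyond the scatter).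

Compound 4 `C=CC1=C(C(=O)Nc2ccccc2OC)C(c2ccc(OC)cc2)OC1` introduces (2-methoxyphenyl in place of 4-methylbenzyl on an amide-type nitrogen). Neither measured step removes the saturated carbon between the nitrogen and the ring, nor adds a methoxy group to the ring on the nitrogen; both only show that small changes at this position shift values between a number and the limit. Compound 4 is therefore expected to fall back toward weaker inhibition, with an estimated step of a 1.7-fold higher number from compound 3 to compound 4 (0.24 log units; within the scatter). The value of compound 4 in this assay is estimated at 75000 nM, within a range from 25000 nM to 200000 nM.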

Compound 4, half-maximal inhibitory concentration: > 100000 nM
Compound 4: only a limit was reported; the forecaster's own chance of this, stated with the estimate: 45%; middle value at least 1.3-fold (0.12 log units) away from the limit.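

In this assay compound 4 gives > 100000 nM, which is a limit and not a number. Putting 2-methoxyphenyl in place of 4-methylbenzyl on the amide-type nitrogen gives up the one measurable value in the series, with an at least 2.3-fold higher number from compound 3 to compound 4 (0.36 log units; beyond the scatter), and this is the first step shown that changes the kind of group carried on that nitrogen rather than a chain or a ring hydrogen. The steps from compound 1 and from compound 2 to compound 4 join limit to limit and cannot be read, which leaves compound 3 as the only compound with a number: the limit of > 100000 nM in this assay, at which 3 of the 4 values shown sit.

Compound 4 loses the saturated carbon on the nitrogen and gains a methoxy group in the same change, and the compounds shown do not tell which of the two accounts for the step. Also open, on these data alone, is how a 4-chlorobenzyl or a 4-aminobenzyl group on the amide-type nitrogen would read, and whether any such group would move the value further from the limit than the methyl group of compound 3 does.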